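The source may report more compounds than this note shows. Statements on the series, on what has been measured and on what is new or still open speak of the compounds shown alone.

Working notes on the series. The shared core is carried by compound 1 `Cc1n[nH]c2ccc(-c3nc4cnc(N5CCN(C)CC5)cn4c3Nc3ccc(F)cc3)cc12`, which in a functional assay on MV4-11 cells (Homo sapiens) for inhibition, with a stated time of 120 h (a lower number here means a stronger inhibitor, a higher number a weaker inhibitor), gives 32300 nM. Compound 2 `Cc1n[nH]c2ccc(-c3nc4cnc(N5CCN(C)CC5)cn4c3Nc3ccccc3)cc12` gives "not determined" (no result reported) in this assay. Compound 3 `Cc1n[nH]c2ccc(-c3nc4cnc(N5CCN(C)CC5)cn4c3Nc3ccc(F)cc3Br)cc12` gives 3830 nM in this assay, the lowest of the two numbers available; the step of an 8.4-fold lower number from compound 1 to compound 3 (0.93 log units; beyond the scatter) is the only measured one and lies beyond the scatter. Compound 4 `Cc1n[nH]c2ccc(-c3nc4cnc(N5CCN(C)CC5)cn4c3Nc3ccc(Cl)cc3Cl)cc12` differs from compound 3 by 2,4-dichlorophenyl in place of 2-bromo-4-fluorophenyl on a nitrogen on an aromatic ring. Among the compounds with values here, no measured step covers the exchange of one halogen for another on this ring, so the expectation rests on compound 3 alone. The change a 1.1-fold lower number from compound 3 to compound 4 (0.04 log units; within the scatter) is expected to stay within the scatter. Compound 4 is therefore estimated at 3500 nM in this assay, with a range from 1200 nM to 10000 nM.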

Compound 4, half-maximal inhibitory concentration: 4720 nM
Compound 4: middle estimate off by 1.3-fold (0.13 log units), on the low side; the measured number falls inside the stated range.
By their numbers in this assay, from the lowest: compounds 3 and 4 (each within the scatter of the next); then compound 1.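

In this assay, 2,4-dichlorophenyl in place of 2-bromo-4-fluorophenyl on a nitrogen on an aromatic ring gives a 1.2-fold higher number from compound 3 to compound 4 (0.09 log units; within the scatter), so these two groups are not told apart here. Against 4-fluorophenyl, the 2,4-dichlorophenyl group gives a 6.8-fold lower number from compound 1 to compound 4 (0.84 log units; beyond the scatter), showing that the improvement is not confined to the bromo compound. No evidence on the reason for either result is available. Open, as far as these compounds go, is whether a methoxy group or an amine on this phenyl ring would hold the number, and how much each chlorine of compound 4 contributes alone.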